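The source may hold more compounds than are shown below. What is called first, only, known or untested is meant among the compounds shown, and "the series" means these compounds.

Measured compounds:
Compound 1 `O=S(=O)(Nc1cc(-c2cnc3[nH]ncc3c2)cnc1Cl)c1ccccc1`: 4400 nM
Compound 2 `O=S(=O)(Nc1cc(-c2cnc3[nH]nc(-c4ccccc4)c3c2)cnc1Cl)c1ccccc1`: 4190 nM

In a functional assay on T47D cells (Homo sapiens) for inhibition, read by sulforhodamine B assay, with a stated time of 72 h (a lower number here means a stronger inhibitor of growth, a higher number a weaker inhibitor of growth), compound 1 gives 4400 nM, and compound 2 gives 4190 nM. Of the two numbers, that of compound 2 is the smaller, but the step of a 1.1-fold lower number from compound 1 to compound 2 (0.02 log units; within the scatter) falls within the scatter, so the two compounds cannot be separated on these data. Compound 3 `O=S(=O)(Nc1cc(-c2cnc3[nH]nc(-c4ccncc4)c3c2)cnc1Cl)c1ccccc1` is the next member of the series; it differs from compound 2 in one place: pyridin-4-yl in place of phenyl on an aromatic carbon.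

Among the measured compounds shown here, the one measured step that bears on this position is a 1.1-fold lower number from compound 1 to compound 2 (0.02 log units; within the scatter), which put the phenyl in place of hydrogen at the same aromatic carbon and changed nothing beyond the scatter. For the measured compounds named here, no measured pair exchanges phenyl for pyridin-4-yl, so the effect of the ring nitrogen on the number is not known from these compounds. Since the phenyl itself left the number unchanged, the replacement is expected to give a step of a 1.0-fold lower number from compound 2 to compound 3 (0.02 log units; within the scatter), that is, none beyond the scatter. Compound 3 is therefore estimated at 4000 nM, with a range from 1500 nM to 11000 nM.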

Compound 3, concentration for 50% growth inhibition: 520 nM
Beside the measured number, compound 3's estimate is 7.7-fold (0.89 log units) above it; the measured number lies below the stated range.
By their numbers in this assay, from the lowest: compound 3; then compounds 2 and 1 (each within the scatter of the next).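

In this assay, this aromatic carbon of the five-membered ring proves sensitive to the group it carries, which the earlier pair could not show: phenyl in place of hydrogen gave only a 1.1-fold lower number from compound 1 to compound 2 (0.02 log units; within the scatter), whereas pyridin-4-yl in place of phenyl gave an 8.1-fold lower number from compound 2 to compound 3 (0.91 log units; beyond the scatter). Pyridin-4-yl in place of hydrogen gave an 8.5-fold lower number from compound 1 to compound 3 (0.93 log units; beyond the scatter), so among these three compounds, a six-membered aromatic ring at this carbon goes with a lower number only when that ring holds a nitrogen, even though phenyl and pyridin-4-yl have the same count of heavy atoms. Nothing available here accounts for the effect of this single exchange of atoms.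

On these data alone, it remains open whether the ring nitrogen must stand where it does in pyridin-4-yl, or whether pyridin-3-yl or pyridin-2-yl at the same carbon would give a step of similar size. As far as these compounds go, it is also open whether a phenyl carrying an amine or a carboxylic acid, or a saturated ring such as piperidin-4-yl, would lower the number in the same way.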